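A single cytotoxicity figure and a piperazine swap

The source may report more compounds than this note shows. Statements on the series, on what has been measured and on what is new or still open speak of the compounds shown alone.

Two compounds sharing one core have been taken into a functional assay on SK-BR-3 cells (Homo sapiens) for cytotoxicity, read by MTT assay, with a stated time of 72 h; on this read-out higher numbers stand for weaker inhibition and lower numbers for stronger inhibition. For compound 1 `NCCCNc1c(C(=O)NCc2ccc(F)cc2)nc(Br)c2cccnc12` the entry reads "not determined" (no result reported). Among the compounds with values here, that leaves compound 2 `N[C@H]1CC[C@H](Nc2c(C(=O)NCc3ccc(F)cc3)nc(Br)c3cccnc23)CC1`, at 2000 nM, with the only number available and nothing to be ranked against. Compound 3 `O=C(NCc1ccc(F)cc1)c1nc(Br)c2cccnc2c1N1CCNCC1` carries piperazin-1-yl in place of (4-aminocyclohexyl)amino on an aromatic carbon, para to a bromo group (piperazin-1-yl in place of (4-aminocyclohexyl)amino on an aromatic carbon). Within the data shown here, no step between measured compounds is available to size this change in this assay. The expectation therefore stays loose: a small weakening is expected, though a step no larger than the scatter would fit as well. The estimated change is a 1.5-fold higher number from compound 2 to compound 3 (0.18 log units; within the scatter). For compound 3 the expected value is 3000 nM, with an estimated range from 900 nM to 10000 nM.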

Compound 3, half-maximal inhibitory concentration: 6000 nM
The estimate for compound 3 lay 2.0-fold (0.30 log units) below the measured number; measured number inside the range.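

The position para to a bromo group now has its first measured step: in this assay there is a 3.0-fold higher number from compound 2 to compound 3 (0.48 log units; beyond the scatter) on putting piperazin-1-yl in place of (4-aminocyclohexyl)amino, a modest move beyond the scatter. This position on the shared core therefore responds when a six-membered non-aromatic ring of carbon only gives way to one with hetero atoms, and the lower number of the pair stays with compound 2. Nothing available here bears on the reason for this step.

On these data alone, how a morpholin-4-yl or a 4-methylpiperazin-1-yl group would read at this position remains open. Within the data shown here, the open chain of compound 1 also cannot be placed against either ring, since its entry reads "not determined" (no result reported) and gives no step in this assay to compare.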